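Replacing 2,4-dimethylphenyl with pyridin-2-yl on the shared core

A few compounds are considered here, and "the series" means these few. Any claim that something is new, unique, unknown or untested is made for them only; others in the source may bear on it.

In a functional assay on B16-F10 cells (Mus musculus) for antiproliferative activity, read by MTT assay, with a stated time of 48 h (on this read-out lower numbers stand for stronger inhibition and higher numbers for weaker inhibition), compound 1 (`COc1ccccc1N1CCN(C(=O)/C=C/c2ccc(O)c(O)c2)CC1`) gives 1.23 ug/mL and compound 2 (`Cc1ccc(N2CCN(C(=O)/C=C/c3ccc(O)c(O)c3)CC2)c(C)c1`) gives 1.43 ug/mL and so stands level with it, within the usual scatter of repeated measurements. The next structure is compound 3 (`O=C(/C=C/c1ccc(O)c(O)c1)N1CCN(c2ccccn2)CC1`), which has pyridin-2-yl in place of 2,4-dimethylphenyl on an amine nitrogen in a ring. The swap counts out as follows: pyridin-2-yl in place of 2,4-dimethylphenyl on an amine nitrogen in a ring and the rest of the molecule stays the same.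

Going by the values given here, only one measured step bears on this: a 1.2-fold higher number from compound 1 to compound 2 (0.07 log units; within the scatter) at that same amine nitrogen, and it lies within the scatter. That step exchanged one aromatic ring of carbon only for another, so the data hold no measured case of a ring with a hetero atom entering here. Nothing measured points in either direction, and the expected size of the change is a 1.0-fold higher number from compound 2 to compound 3 (0.02 log units; within the scatter) with no shift beyond the scatter. Compound 3 is estimated at 1.5 ug/mL with an expected range from 0.7 ug/mL to 3.2 ug/mL for the measurement still to come.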

Compound 3, half-maximal inhibitory concentration: 3.01 ug/mL
The estimate for compound 3 lay 2.0-fold (0.30 log units) below the measured number; low and high end bracket the measured number.
By their numbers in this assay, from the lowest: compounds 1 and 2 (each within the scatter of the next); then compound 3.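

In this assay the change to pyridin-2-yl on the amine nitrogen in a ring brings a 2.1-fold higher number from compound 2 to compound 3 (0.32 log units; beyond the scatter) and, measured against the 2-methoxyphenyl compound, a 2.4-fold higher number from compound 1 to compound 3 (0.39 log units; beyond the scatter) in both cases as a modest shift. Compound 3 is therefore the weakest inhibitor of the three, and this position, which showed no change beyond the scatter when one carbon-only aromatic ring replaced another, is now seen to respond to the ring it carries. Nothing available gives a reason for this shift.

The step to compound 3 changes two things at once: a ring nitrogen enters, and the methyl or methoxy groups carried by the earlier rings leave, so the compounds shown cannot say which of the two matters. A plain phenyl group would help separate these two changes, as would a pyridin-2-yl ring bearing a methyl or methoxy group, while pyridin-4-yl would show whether the place of the ring nitrogen counts.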